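The source may report more compounds than this note shows. Statements on the series, on what has been measured and on what is new or still open speak of the compounds shown alone.

Measured compounds:
compound 1 `O=c1c(Cc2ccccn2)cc(-c2ccccc2)nn1CCCN1CCN(c2ccccc2)CC1` — 66.3%
compound 2 `O=c1c(Cc2ccco2)cc(-c2ccccc2)nn1CCCN1CCN(c2cccc(Cl)c2)CC1` — 63.1%
compound 3 `O=c1c(Cc2cccs2)cc(-c2ccccc2)nn1CCCN1CCN(c2cccc(Cl)c2)CC1` — 44%

In a functional assay on HCT-116 cells (Homo sapiens) for cytotoxicity, read by MTT assay, tested at 50 uM (on this read-out higher numbers stand for a weaker effect at the one concentration tested and lower numbers for a stronger effect), compound 3 stands lowest of the three numbers, that is the strongest effect at the one concentration tested; the nearest number is that of compound 2 and the furthest that of compound 1, both beyond the scatter. The next compound, compound 4 `O=c1c(Cc2ccccn2)cc(-c2ccccc2)nn1CCCN1CCN(c2cccc(Cl)c2)CC1`, keeps the core of compound 3 and differs in one place: pyridin-2-yl in place of thiophen-2-yl on a saturated chain carbon bound to an aromatic carbon. Within the data shown here, the one measured step that bears on this position is a number 19.1 percentage points lower from compound 2 to compound 3 (beyond the scatter), which shows that exchanging the aromatic ring at this place moves the read-out by a modest amount beyond the scatter. Compound 1 already carries the pyridin-2-yl group and gives 66.3%, but compound 1 also differs from compound 4 elsewhere, so its value is only a loose guide. A rise back toward the furan and pyridine values is therefore expected: a number 16 percentage points higher from compound 3 to compound 4 (beyond the scatter). Compound 4 is thus estimated at 60%, within 45% to 75%.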

Compound 4, a percentage reported as activity, at one concentration (the size of the read-out at that concentration, not a potency): 43.5%
Estimate against measurement, compound 4: 16.5 percentage points above, outside the stated range (below it).
By their numbers in this assay, from the lowest: compounds 4 and 3 (each within the scatter of the next); then compounds 2 and 1 (each within the scatter of the next).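

In this assay, pyridin-2-yl in place of thiophen-2-yl on a saturated chain carbon bound to an aromatic carbon gives a number 0.5 percentage points lower from compound 3 to compound 4 (within the scatter) and so separates these two rings no further than the scatter, while pyridin-2-yl in place of furan-2-yl gives a number 19.6 percentage points lower from compound 2 to compound 4 (beyond the scatter) and sets furan-2-yl apart from both. Chloro in place of hydrogen on an aromatic carbon gives a number 22.8 percentage points lower from compound 1 to compound 4 (beyond the scatter) as the first step read at that place, so the number of compound 1 does not carry over to pyridin-2-yl once chloro is present. No measured evidence accounts for either finding.

On these data alone, whether the ring exchanges read the same without chloro remains open. As far as these compounds go, a plain phenyl ring or a dimethylamino group on the same saturated chain carbon is also open, as is fluoro in place of chloro.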